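The source may hold more compounds than are shown below. What is called first, only, known or untested is meant among the compounds shown, and "the series" means these compounds.

In a functional assay on DU-145 cells (Homo sapiens) for inhibition (a lower number here means a stronger inhibitor of growth, a higher number a weaker inhibitor of growth), three compounds have been measured so far. Compound 1 (`O=S(=O)(/C=C/c1ccc(Cl)cc1Cl)Cc1ccc(Nc2ncnc3ccccc23)cc1`) gives 3000 nM, compound 2 (`O=S(=O)(/C=C/c1ccc(Br)cc1)Cc1ccc(Nc2ncnc3ccc(Br)cc23)cc1`) gives 3000 nM, and compound 3 (`O=S(=O)(/C=C/c1ccc(O)cc1)Cc1ccc(Nc2ncnc3ccc(Br)cc23)cc1`) gives 3000 nM, so compound 3 stands level with the other two. Compound 4 (`O=S(=O)(/C=C/c1ccc(Cl)cc1Cl)Cc1ccc(Nc2ncnc3ccc(Br)cc23)cc1`) has not yet been measured. It departs from compound 3 in one group: 2,4-dichlorophenyl in place of 4-hydroxyphenyl on a double-bonded chain carbon bound to a double-bonded chain carbon. The exchange puts 2,4-dichlorophenyl in place of 4-hydroxyphenyl on a double-bonded chain carbon bound to a double-bonded chain carbon. Among the compounds with values here, the one measured step that bears on this is hydroxy in place of bromo on an aromatic carbon, which shows no change at the digits printed from compound 2 to compound 3 (within the scatter). Compound 4 differs elsewhere from compound 1, which also carries the 2,4-dichlorophenyl group and gives 3000 nM. With no measured step beyond the scatter to draw on, the expected step is no change at the digits printed from compound 3 to compound 4 (within the scatter), and no shift beyond the scatter is anticipated. For compound 4 the estimated value in this assay is 3000 nM, with an expected range from 1500 nM to 6000 nM.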

Compound 4, concentration for 50% growth inhibition: 2000 nM
Compound 4: middle estimate off by 1.5-fold (0.18 log units), on the high side; the range from low to high includes it.
By their numbers in this assay, from the lowest: compounds 4, 1, 2 and 3 (each within the scatter of the next).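

In this assay, 2,4-dichlorophenyl on a double-bonded chain carbon bound to a double-bonded chain carbon gives a 1.5-fold lower number from compound 3 to compound 4 (0.18 log units; within the scatter) when it replaces 4-hydroxyphenyl and a 1.5-fold lower number from compound 2 to compound 4 (0.18 log units; within the scatter) when it replaces 4-bromophenyl, so with the rest of the structure held, this position takes all three of these aryl groups without a shift beyond the scatter, even as the hydrogen-bond donor and acceptor counted on 4-hydroxyphenyl leave. The change on the core can now be read with the 2,4-dichlorophenyl group held, and bromo in place of hydrogen on an aromatic carbon gives a 1.5-fold lower number from compound 1 to compound 4 (0.18 log units; within the scatter) and stays within the scatter as well. Nothing available explains these small steps.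

From the compounds shown here alone, all four compounds lie within the scatter of one another, so what would move this number remains unknown. Going by these compounds, it is open whether an amine or a carboxylic acid on that phenyl ring, or a longer chain in place of the ethenyl link, would produce a step beyond the scatter.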